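Azido-to-benzylsulfanyl change on the shared deoxyribosyl core

A few compounds are considered here, and "the series" means these few. Any claim that something is new, unique, unknown or untested is made for them only; others in the source may bear on it.

Measured compounds in a functional assay on EL4 cells (Mus musculus) for inhibition, tested at 100 uM; on this read-out lower numbers stand for less inhibition and higher numbers for more inhibition at the one concentration tested (going by the name of the read-out):
- compound 1, `[N-]=[N+]=Nc1nccc2c1ncn2[C@H]1C[C@H](O)[C@@H](CO)O1`: 13%
- compound 2, `CN(C)c1[nH]ccc2ncnc1-2`: 25%
- compound 3, `[O-][n+]1ccc2c(c1)ncn2[C@H]1C[C@H](O)[C@@H](CO)O1`: < 5%

Compound 1 gives 13% in this assay, the lowest of the two numbers obtained. Compound 2 sits higher, at 25%, and that gap lies beyond the usual scatter of repeated measurements. Compound 3 is reported only as a limit in this assay, not as a number: the limit of < 5% in this assay, at which 1 of the 3 values shown sits. Across the three, inhibition at the single concentration tested is low throughout.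

Compound 4, `OC[C@H]1O[C@@H](n2cnc3c(SCc4ccccc4)nccc32)C[C@@H]1O`, has not yet been measured. It differs from compound 1 in one place: benzylsulfanyl in place of azido on an aromatic carbon. Among the compounds with values here, no measured pair in the set shares this change, so the size of the step is open. Given that every number so far is small and that compound 1 sits at the low end, a step of modest size in either direction is expected, and a move beyond the scatter is not assumed.

For compound 4 the expected value in this assay is 20%, within 5% to 45%, corresponding to an expected step of a number 7 percentage points higher from compound 1 to compound 4 (within the scatter) that stays within the scatter of this assay.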

Compound 4, a percentage reported as inhibition, at one concentration (the size of the read-out at that concentration, not a potency): 11%
Beside the measured number, compound 4's estimate is 9 percentage points above it; measured number inside the range.
By their numbers in this assay, from the lowest: compounds 4 and 1 (each within the scatter of the next); then compound 2. At a limit, below all of these: compound 3.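

In this assay, within the data shown here, the first one-place comparison puts benzylsulfanyl in place of azido on the aromatic carbon next to the ring nitrogen, and the step is a number 2 percentage points lower from compound 1 to compound 4 (within the scatter) on the shared core. At this position, a group of 8 heavy atoms carrying a six-membered aromatic ring of carbon only therefore reads the same, within the scatter, as a group of 3 nitrogen atoms with no ring. The earlier compounds shown here could not show this, since no two of them differed in one place, and the finding holds for this single pair at the one concentration tested, with no wider pattern to be drawn from it.

As far as these compounds go, whether a carboxylic acid, a primary amine or a shorter methylsulfanyl group on this same aromatic carbon would give a read-out clearly apart from these two values remains open, as does any behaviour of this pair at other concentrations. Nothing in the data at hand bears on why the two groups read alike.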